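The source may report more compounds than this note shows. Statements on the series, on what has been measured and on what is new or still open speak of the compounds shown alone.

Measured compounds:
- compound 1, `CCCCCOC(=O)C(=O)Nc1cccccc1=O`, 12%
- compound 2, `O=C(O)C(=O)Nc1cccccc1=O`, 38%; 53%; 32% (3 entries)

In a functional assay on the whole organism (strain Sprague-Dawley CD) for inhibition, with Rattus norvegicus as the target, read by paw edema, at a dose of 30 mg/kg by the oral route (on this read-out lower numbers stand for a weaker effect and higher numbers for a stronger effect at the one dose given), compound 1 gives 12%, the lowest of the numbers shown. Compound 2, which carries a free carboxylic acid in place of the ester, gives 38%; 53%; 32% (3 entries); its repeated entries the several entries of compound 2 in this assay, 38%; 53%; 32% (3 entries) show how much one and the same compound can move between measurements, and it sits clearly higher than compound 1 on the numbers shown. Going by the values given here, no step between measured compounds is known here, so only those two sets of values can be compared.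

Compound 3, `NNC(=O)C(=O)Nc1cccccc1=O`, has not been measured. It differs from compound 1 by aminoamino in place of pentyloxy on a carbonyl carbon. Among the compounds with values here, since no measured step tells how large such a change is, the expectation is a modest gain, and the step of a number 13 percentage points higher from compound 1 to compound 3 (beyond the scatter) is the estimate. Compound 3 is expected to give about 25%, within 5% to 50%.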

Compound 3, a percentage reported as inhibition, in the whole organism at one dose (the size of the read-out at that dose, not a potency): 41%
Compound 3: middle estimate off by 16 percentage points, on the low side, within the range that was stated.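

Going by these compounds alone, at this carbonyl carbon, the exchange of pentyloxy for aminoamino in this assay gives a number 29 percentage points higher from compound 1 to compound 3 (beyond the scatter) and provides the first size of a change at this place. Until now, the free carboxylic acid of compound 2 was the only group shown with values above that of compound 1, but compound 3 carries no carboxylic acid, gives 41% and falls among the entries of compound 2 at 38%; 53%; 32% (3 entries) in the same assay. Compound 3 and compound 2 cannot be ranked, as one compound alone moves this far between entries: the several entries of compound 2 in this assay, 38%; 53%; 32% (3 entries).

From the compounds shown here alone, it remains open whether the rise comes from losing the pentyloxy chain or from gaining aminoamino, as both happen in one step. An ethoxy chain or a plain amino group on the same carbonyl carbon would help to separate the two.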